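The compounds below may be only part of what the source reports. "The series", "measured", "known", "first", "only" and "open" are said of these compounds alone.

The study concerns a small set of compounds built on the shared core of compound 1 `CCCCC(OC)c1cccc(NC(=O)NCCCCl)c1`, which carries a (3-chloropropyl)amino group on its carbonyl carbon; in a functional assay on M21 cells (Homo sapiens) for antiproliferative activity, with a stated time of 48 h (a higher number here means a weaker inhibitor, a lower number a stronger inhibitor), compound 1 gives 51000 nM. Compound 2 `CCCCC(O)c1cccc(NC(=O)CCCl)c1` has a hydrogen on the oxygen on the saturated carbon and a 2-chloroethyl group on the carbonyl carbon. In this assay compound 2 reaches only > 100000 nM, which is a limit of the assay and not a number. Compound 3 `CCCCC(OC)c1cccc(NC(=O)CCCl)c1` restores the methyl on that oxygen. In this assay compound 3 likewise sits at > 100000 nM, again a limit and not a number. Compound 3 therefore stands at the limit of > 100000 nM in this assay, at which 2 of the 3 values shown sit. The step of an at least 1.9-fold higher number from compound 1 to compound 3 (0.29 log units; that floor lies within the scatter) shows only its floor, and a step that the two limits leave unreadable from compound 2 to compound 3. Compound 4 `CCCCC(OC)c1cccc(NC(=O)CCCCl)c1` differs from compound 3 by chloromethyl in place of chloro on a saturated chain carbon, two bonds along the chain from a carbonyl carbon. Neither measured step concerns this part of the acyl chain, so no direction can be read from them. Compound 4 is expected to remain at the limit, with a number no higher from compound 3 to compound 4 (the limit leaves the size open) as the expected step and an estimate of 100000 nM within a range of 30000 nM to 300000 nM.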

Compound 4, half-maximal inhibitory concentration: > 100000 nM
Compound 4: only a limit was reported (the forecaster's own chance of this, stated with the estimate: 80%); the middle value sits exactly at the limit.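

In this assay compound 4 gives > 100000 nM, which is a limit and not a number, so chloromethyl in place of chloro at this place on the chain does not yield a readable value. The new comparison with compound 1 sets 3-chloropropyl against (3-chloropropyl)amino on a carbonyl carbon, and it shows only a floor: an at least 1.9-fold higher number from compound 1 to compound 4 (0.29 log units; that floor lies within the scatter). The step between compound 3 and compound 4 cannot be read, so the effect of this change on the chain stays unknown, and the set now rests largely on one limit: the limit of > 100000 nM in this assay, at which 3 of the 4 values shown sit.

The compounds shown leave open how a longer chain, or an amine in place of the chloro, would read in this assay. They also leave open how far the true difference between compound 1 and compound 4 exceeds that floor.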